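Swapping Fluoro for Methyl on the Urea Phenyl

The source may report more compounds than this note shows. Statements on the series, on what has been measured and on what is new or still open speak of the compounds shown alone.

Compound 2 `CCN(CC)CCCNc1nc(-c2ccc(NC(=O)Nc3ccc(F)cc3)cc2)nc2c(Cl)c(Cl)sc12` is the stronger of the two measured compounds in a functional assay on HT-29 cells (Homo sapiens) for cytotoxicity, read by MTT assay, with a stated time of 72 h; a lower number here means a stronger inhibitor, a higher number a weaker inhibitor: compound 2 gives 350 nM, whereas compound 1 `CN(C)CCNc1nc(-c2ccc(NC(=O)Nc3ccc(F)cc3)cc2)nc2c(Cl)c(Cl)sc12` gives 890 nM. Among the measured compounds shown here, the only measured step, a 2.5-fold lower number from compound 1 to compound 2 (0.41 log units; beyond the scatter), concerns the amine-bearing chain at the far side of the shared core. Compound 3 `CCN(CC)CCCNc1nc(-c2ccc(NC(=O)Nc3ccc(C)cc3)cc2)nc2c(Cl)c(Cl)sc12` differs from compound 2 in methyl in place of fluoro on an aromatic carbon. For the measured compounds named here, no measured step touches this part of the molecule, so the step from compound 1 to compound 2 does not bear on it directly; the expectation rests only on how small the swap is, one heavy atom exchanged for one heavy atom. Compound 3 is therefore expected to show no step beyond the scatter in this assay, that is no change at the digits printed from compound 2 to compound 3 (within the scatter), with an estimated value of 350 nM and a range from 120 nM to 1000 nM.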

Compound 3, half-maximal inhibitory concentration: 890 nM
Compound 3: the middle estimate sits 2.5-fold (0.41 log units) below what was measured; the range from low to high includes it.
By their numbers in this assay, from the lowest: compound 2; then compounds 1 and 3 (each within the scatter of the next).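

In this assay, putting methyl in place of fluoro on the urea phenyl gives a 2.5-fold higher number from compound 2 to compound 3 (0.41 log units; beyond the scatter). So this part of the molecule, well away from the amine-bearing chain, responds to the exchange of one heavy atom for another, and a step beyond the scatter can arise here as well as on the chain. Nothing shown offers a measured reason for the difference between these two groups.

As far as these compounds go, with only 4-fluorophenyl and 4-methylphenyl to compare, it remains open where a 4-chlorophenyl, a 4-methoxyphenyl or a plain phenyl would fall. From the compounds shown here alone, it is also open whether the same swap would give a similar step on the dimethylamino chain of compound 1, since methyl appears here only with the diethylamino chain.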